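The source may report more compounds than this note shows. Statements on the series, on what has been measured and on what is new or still open speak of the compounds shown alone.

Three measured compounds share one core: compound 1 `O=C(Nc1ccnnc1)c1cc(C(F)(F)F)ccc1OCc1ccccc1`, compound 2 `O=C(Nc1ccnnc1)c1cc(N2CCCCC2)ccc1OCc1ccccc1` and compound 3 `CN1CCC(c2ccc(OCc3ccccc3)c(C(=O)Nc3ccnnc3)c2)CC1`. In an assay on Sf9 cells for inhibition of Leucine-rich repeat serine/threonine-protein kinase 2 (Homo sapiens), read by TR-FRET, with stated times of 30 min and 2 h (on this read-out lower numbers stand for stronger inhibition and higher numbers for weaker inhibition), compound 1 gives 15.9 nM. In this assay compound 2 gives 25.1 nM, and compound 3 gives 20 nM. Compound 3 thus holds the second highest of the three numbers, though all three lie within the scatter of one another: a 1.6-fold higher number from compound 1 to compound 2 (0.20 log units; within the scatter), a 1.3-fold higher number from compound 1 to compound 3 (0.10 log units; within the scatter) and a 1.3-fold lower number from compound 2 to compound 3 (0.10 log units; within the scatter).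

Compound 4 `O=C(Nc1ccnnc1)c1cc(N2CCC(F)CC2)ccc1OCc1ccccc1` is the next compound, differing from compound 3 only in 4-fluoropiperidin-1-yl in place of 1-methylpiperidin-4-yl on an aromatic carbon. The step that bears most directly on this change is the one in which the same place carries piperidin-1-yl in compound 2 and 1-methylpiperidin-4-yl in compound 3, a 1.3-fold lower number from compound 2 to compound 3 (0.10 log units; within the scatter), since compound 4 carries a piperidine joined through its nitrogen as compound 2 does. The other two steps, a 1.6-fold higher number from compound 1 to compound 2 (0.20 log units; within the scatter) and a 1.3-fold higher number from compound 1 to compound 3 (0.10 log units; within the scatter), show that trifluoromethyl, piperidin-1-yl and 1-methylpiperidin-4-yl at this place all give numbers in the same band. For the measured compounds named here, the 4-fluoropiperidin-1-yl group itself has no measured precedent here. On this basis compound 4 is expected to show a 1.1-fold higher number from compound 3 to compound 4 (0.04 log units; within the scatter), no step beyond the scatter. The estimate for compound 4 in this assay is 22 nM, within a range of 9 nM to 55 nM.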

Compound 4, half-maximal inhibitory concentration: 39.8 nM
For compound 4 the middle estimate is 1.8-fold (0.26 log units) below the measured one; measured number inside the range.
By their numbers in this assay, from the lowest: compounds 1, 3, 2 and 4 (each within the scatter of the next, the first and the last beyond it).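

For the compounds shown here, at the place para to the benzyloxy group, the earlier compounds gave no step beyond the scatter, and compound 4 supplies the first: in this assay, 4-fluoropiperidin-1-yl in place of trifluoromethyl gives a 2.5-fold higher number from compound 1 to compound 4 (0.40 log units; beyond the scatter). Against the two compounds with a saturated ring at this place, the result stays inside the scatter, with a 1.6-fold higher number from compound 2 to compound 4 (0.20 log units; within the scatter) for fluoro in place of hydrogen on a saturated ring carbon and a 2.0-fold higher number from compound 3 to compound 4 (0.30 log units; within the scatter) for 4-fluoropiperidin-1-yl in place of 1-methylpiperidin-4-yl, so no separate effect can be assigned to the fluoro, and the modest separation holds only for the pair of compound 1 and compound 4. Nothing measured here accounts for any of these steps.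

The compounds shown leave open whether a morpholine or a piperazine joined through its nitrogen would stay in the same band at this place, and whether a fluoro on another carbon of the piperidine ring would give a similar number. They also leave open how a carboxylic acid or a primary amine carried on the saturated ring would read in this assay.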